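Notes on the step from compound 3 to compound 4

This account rests on a few compounds, and the source may have more. Where it says the series, first, only, none or still open, it means among the compounds named here.

Values in a functional assay on HT-29 cells (Homo sapiens) for antiproliferative activity, read by sulforhodamine B assay, with a stated time of 48 h; on this read-out higher numbers stand for weaker inhibition and lower numbers for stronger inhibition:
- compound 1 `Cc1ccc(NS(=O)(=O)c2ccc(N3CCNC3=O)cc2)cc1`: 480 nM
- compound 2 `O=C1NCCN1c1ccc(S(=O)(=O)Nc2ccc(Br)cc2)cc1`: 300 nM
- compound 3 `Cc1cccc(NS(=O)(=O)c2ccc(N3CCNC3=O)cc2)c1C`: 190 nM

Compound 3 stands level with compound 2, given a 1.6-fold lower number from compound 2 to compound 3 (0.20 log units; within the scatter), and apart from compound 1, given a 2.5-fold lower number from compound 1 to compound 3 (0.40 log units; beyond the scatter).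

The next compound is compound 4 `O=C1NCCN1c1ccc(S(=O)(=O)Nc2cccc(Cl)c2)cc1`, with 3-chlorophenyl in place of 2,3-dimethylphenyl on a sulfonamide nitrogen.

Among the measured compounds shown here, no measured compound carries this group. The closest evidence is the two steps above, together with a 1.6-fold lower number from compound 1 to compound 2 (0.20 log units; within the scatter). All three are small, so only a small step is expected in this assay, most likely within the scatter. For the measured compounds named here, compound 2, at 300 nM, is the only measured compound with a halogen on that phenyl, so a slightly higher number than for compound 3 is expected. The estimated step is a 1.5-fold higher number from compound 3 to compound 4 (0.17 log units; within the scatter). The expected value for compound 4 is 280 nM, with an estimated range of 120 nM to 650 nM.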

Compound 4, half-maximal inhibitory concentration: 55 nM
Compound 4: middle estimate off by 5.1-fold (0.71 log units), on the high side, outside the stated range (below it).
By their numbers in this assay, from the lowest: compound 4; then compounds 3, 2 and 1 (each within the scatter of the next, the first and the last beyond it).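

In this assay, among the compounds shown here, the group on the sulfonamide nitrogen can move the number by more than the earlier compounds suggested: 3-chlorophenyl gives steps beyond the scatter against all three others (a 3.5-fold lower number from compound 3 to compound 4 (0.54 log units; beyond the scatter); a 5.5-fold lower number from compound 2 to compound 4 (0.74 log units; beyond the scatter); an 8.7-fold lower number from compound 1 to compound 4 (0.94 log units; beyond the scatter)). Among the earlier compounds, the largest step was only (a 2.5-fold lower number from compound 1 to compound 3 (0.40 log units; beyond the scatter)), so compound 4 is the first to stand clearly apart from the rest of the series, and the halogen-bearing compound 2 shows that a halogen on this phenyl does not by itself give such a low number. Nothing available bears on why this change lowers the number.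

For the compounds shown here, still open is whether a phenyl carrying a methoxy group or an amine on the sulfonamide nitrogen would stay near compound 4 or return to the level of the earlier compounds. The compounds shown also leave open how any change to the shared core, such as a longer chain on its urea nitrogen, would affect the number.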